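From Ethylphenyl to Naphthyl on the Amide Carbonyl

A few compounds are considered here, and "the series" means these few. Any claim that something is new, unique, unknown or untested is made for them only; others in the source may bear on it.

Of the compounds shown here, two sharing one core have been measured so far. Compound 1 `CN1[C@@H]2c3[nH]c4ccccc4c3C[C@H]1[C@H](C#N)N1[C@@H](CNC(=O)c3ccc(F)cc3)c3[nH]c4ccccc4c3C[C@@H]21` gives 1370 nM in a functional assay on HT-29 cells (Homo sapiens) for cytotoxicity, read by MTT assay, with a stated time of 72 h; a higher number here means a weaker inhibitor, a lower number a stronger inhibitor. Compound 2 `CCc1ccc(C(=O)NC[C@H]2c3[nH]c4ccccc4c3C[C@H]3[C@H]4c5[nH]c6ccccc6c5C[C@@H]([C@H](C#N)N23)N4C)cc1` gives 3560 nM in this assay. Going by the values given here, the single step between them, a 2.6-fold higher number from compound 1 to compound 2 (0.41 log units; beyond the scatter), is the only measured change, and it leaves compound 2 with the higher of the two numbers, compound 1 being its only neighbour.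

Compound 3 `CN1[C@@H]2c3[nH]c4ccccc4c3C[C@H]1[C@H](C#N)N1[C@@H](CNC(=O)c3ccc4ccccc4c3)c3[nH]c4ccccc4c3C[C@@H]21` has not yet been measured. It differs from compound 2 by naphthalen-2-yl in place of 4-ethylphenyl on a carbonyl carbon; cut one bond further out, the change reads (4-ethylphenyl)carbonyl to (naphthalen-2-yl)carbonyl. Among the compounds with values here, no measured step covers this particular exchange. Within the data shown here, the only step available, a 2.6-fold higher number from compound 1 to compound 2 (0.41 log units; beyond the scatter), shows that a change of the aromatic group attached to the carbonyl carbon moved the number by a modest amount, and nothing more can be drawn from it. For compound 3 the step of a 1.1-fold higher number from compound 2 to compound 3 (0.05 log units; within the scatter) is therefore expected to be small, within or near the usual scatter. For compound 3 the expected value in this assay is estimated at 4000 nM, within a range from 1500 nM to 11000 nM.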

Compound 3, half-maximal inhibitory concentration: 4940 nM
Beside the measured number, compound 3's estimate is 1.2-fold (0.09 log units) below it; the range from low to high includes it.
By their numbers in this assay, from the lowest: compound 1; then compounds 2 and 3 (each within the scatter of the next).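

In this assay, a 1.4-fold higher number from compound 2 to compound 3 (0.14 log units; within the scatter) shows that on a carbonyl carbon whose other neighbour is an amide-type nitrogen, naphthalen-2-yl and 4-ethylphenyl cannot be told apart, although one carries two six-membered aromatic rings and the other a single ring. The second comparison, a 3.6-fold higher number from compound 1 to compound 3 (0.56 log units; beyond the scatter), is beyond the scatter and is close in size to the earlier 2.6-fold higher number from compound 1 to compound 2 (0.41 log units; beyond the scatter), so two different groups in place of 4-fluorophenyl now give a higher number. Compound 1 therefore holds the strongest result of the three, and the earlier single step no longer stands alone.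

What these compounds leave open is whether the fluoro group itself sets compound 1 apart, which plain phenyl or 4-chlorophenyl on the same carbonyl carbon could test. As far as these compounds go, it is also open how the number responds to groups of a different kind at this place, such as pyridin-3-yl, cyclohexyl or a phenyl ring bearing a carboxylic acid. Nothing available here gives a reason for the differences seen among these three compounds.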